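Alkoxy Extension on the Anilide Benzoic Acid Core

The source may hold more compounds than are shown below. What is called first, only, known or untested is meant among the compounds shown, and "the series" means these compounds.

Working notes on a small set of amide-linked benzoic acids. Compound 1 `O=C(O)c1ccc(NC(=O)c2ccc(Oc3ccccc3)cc2)cc1` and compound 2 `CC(Oc1cccc(NC(=O)c2ccc(Oc3ccccc3)cc2)c1)C(=O)O` carry a phenoxy-bearing benzamide on the acid-bearing ring. In an assay on isolated protein for agonist activity at Bile acid receptor (Homo sapiens), read by TR-FRET, with a stated time of 3 h, in the absence of a further agent (a lower number here means that less compound is needed, a higher number that more compound is needed for the effect), compound 1 gives only a limit, > 10000 nM, and no number. Compound 2 likewise returns only a limit in this assay, > 10000 nM. Within the data shown here, compound 3 `COc1cccc(C(=O)Nc2cccc(C(=O)O)c2)c1` is the one compound with a measured number, 1040 nM in this assay, so it stands alone as the only quantified point; the other two values shown rest at the limit of > 10000 nM in this assay, at which 2 of the 3 values shown sit.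

Compound 4 `CC(C)COc1cccc(C(=O)Nc2cccc(C(=O)O)c2)c1` keeps the core of compound 3 and differs in one place: isopropyl in place of hydrogen on a saturated chain carbon bound to an oxygen on an aromatic ring. Among the measured compounds shown here, no step between two measured compounds is available to calibrate this change, so the expectation rests on the structural change alone. In this assay a modest gain in potency is expected for compound 4 relative to compound 3, a step somewhat beyond the usual scatter but not a large one, since the measured number for compound 3 is 1040 nM and the change adds only the three-carbon branch.

Compound 4 is therefore estimated at 400 nM in this assay. That estimate runs from 100 nM to 2000 nM. The expected step amounts to a 2.6-fold lower number from compound 3 to compound 4 (0.41 log units; beyond the scatter).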

Compound 4, half-maximal effective concentration: 1130 nM
Beside the measured number, compound 4's estimate is 2.8-fold (0.45 log units) below it, within the range that was stated.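

Among these compounds, the step in this assay is a 1.1-fold higher number from compound 3 to compound 4 (0.04 log units; within the scatter) and is the first step that can be read between two measured compounds. It shows that going from methoxy to isobutoxy on the shared core leaves the two values within the scatter of each other. The saturated chain carbon bound to an oxygen on an aromatic ring therefore carries the isopropyl group, with its 3 heavy atoms, with no difference that this assay can resolve, and nothing measured here accounts for that outcome.

As far as these compounds go, whether the same holds for a longer chain, a cyclopropylmethyl group or a chain ending in an amine or a hydroxyl group stays open at this position. Among the compounds shown here, only this single step can be read there, and the other values shown give no number to set against it: the limit of > 10000 nM in this assay, at which 2 of the 4 values shown sit.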